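The compounds below may be only part of what the source reports. "The series", "measured", "known", "first", "only" and "open" are said of these compounds alone.

Measured so far:
compound 1 `COc1cc(C)cc(-c2c(-c3ccnc(-c4ccc(N(C)C)cc4)c3)cnn2CC#N)c1` — 41%
compound 2 `Cc1cc(O)cc(-c2nn(CC#N)cc2-c2ccnc(-c3ccc(Oc4ccccc4)cc3)c2)c1` — 92%

In a functional assay on U-251 cells (Homo sapiens) for cytotoxicity, read by sulforhodamine B assay, with a stated time of 48 h, tested at 0.01 uM (a higher number here means a weaker effect of the compound at the concentration tested, a lower number a stronger effect), compound 1 stands lowest of the two numbers; compound 2 gives a number beyond the scatter above it. Compound 3 `COc1cc(C)cc(-c2c(-c3ccnc(-c4ccc(C(C)=O)cc4)c3)cnn2CC#N)c1` differs from compound 1 by acetyl in place of dimethylamino on an aromatic carbon on an aromatic carbon of a six-membered aromatic ring of carbon only, para to a large group. Among the measured compounds shown here, no step between measured compounds covers this change, so the expectation rests on compound 1 alone. The step of a number 14 percentage points higher from compound 1 to compound 3 (beyond the scatter) is expected to be a moderate rise in the number, just beyond the scatter, towards a weaker effect. Compound 3 is estimated at 55%, within a range of 30% to 85%.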

Compound 3, a percentage reported as activity, at one concentration (the size of the read-out at that concentration, not a potency): 89%
The estimate for compound 3 lay 34 percentage points below the measured number, outside the stated range (above it).
By their numbers in this assay, from the lowest: compound 1; then compounds 3 and 2 (each within the scatter of the next).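

The change from 4-(dimethylamino)phenyl to 4-acetylphenyl is a large step, a number 48 percentage points higher from compound 1 to compound 3 (beyond the scatter) in this assay, towards a weaker effect at the concentration tested. This place, on an aromatic carbon para to a large group, is thus sensitive to the group it carries, although dimethylamino and acetyl match in heavy-atom and hydrogen-bond acceptor counts. Nothing at hand accounts for the size of this step.

As far as these compounds go, whether the stronger effect of compound 1 extends to other amines, such as a primary amine or morpholine, remains open. From the compounds shown here alone, a carboxylic acid or a methoxy group at this place also remains open.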